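The source may hold more compounds than are shown below. What is called first, only, known or untested is meant among the compounds shown, and "the series" means these compounds.

Of the compounds shown here, two of one series have been measured so far. Compound 1 `Cc1cc(C(=O)NCN2CCC(c3cccc[n+]3[O-])CC2)ccc1F` is the stronger of the two in a functional assay on HEK293 cells for agonist activity at D(4) dopamine receptor (Homo sapiens), read by FLIPR (a lower number here means that less compound is needed, a higher number that more compound is needed for the effect), where compound 1 gives 50 nM. Compound 2 `COc1cccc(C(=O)NCN2CCC(c3cccc[n+]3[O-])CC2)c1C` differs from it in more than one place, and in this assay compound 2 gives 685 nM, a higher number that lies well beyond the usual scatter of repeated measurements. Compound 1 therefore stands at the lowest number of the pair, and it is the point from which the next compound is judged.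

Compound 3 `Cc1cc(C(=O)NCN2CCC(c3cccc[n+]3[O-])CC2)ccc1Cl` keeps the whole of compound 1 apart from one exchange: chloro in place of fluoro on an aromatic carbon. Among the compounds with values here, no measured pair shows such an exchange on its own, so there is no step to lean on. An exchange of one halogen for another at the same aromatic carbon is usually a small matter, and the expected step of a 1.3-fold lower number from compound 1 to compound 3 (0.10 log units; within the scatter) is within or only slightly beyond the scatter, with a slight lean toward a lower number. Compound 3 is accordingly expected to give about 40 nM in this assay, with a likely range from 15 nM to 120 nM.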

Compound 3, half-maximal effective concentration: 2460 nM
Compound 3: middle estimate off by 62-fold (1.79 log units), on the low side; measured number above the stated range.
By their numbers in this assay, from the lowest: compound 1; then compound 2; then compound 3.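

Exchanging fluoro for chloro on the 4-fluoro-3-methylphenyl group matters greatly in this assay with a 49-fold higher number from compound 1 to compound 3 (1.69 log units; beyond the scatter) as the result, so this aromatic carbon, ortho to a methyl group and para to a large group, is far from indifferent to which halogen it carries. Compound 1 and compound 2 differ in more than one place and could not show this, whereas here a single heavy atom changes, with no ring, hydrogen-bond donor, hydrogen-bond acceptor or net charge entering or leaving. Within the data shown here, the compounds at hand carry no measurement that explains why this one exchange moves the number so far.

Still open, on these data alone, is how other groups at this carbon would behave: a hydrogen, a bromo, a methoxy or a nitrile could each fall near compound 1, near compound 3 or elsewhere. As far as these compounds go, it is also open whether chloro would raise the number as sharply if the neighbouring methyl group of the phenyl ring were replaced by hydrogen.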